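This account rests on a few compounds, and the source may have more. Where it says the series, first, only, none or still open, it means among the compounds named here.

Compound 3 `Cc1ccc(S(=O)(=O)c2cnc3cc(F)ccc3c2N2CCC(C)CC2)cc1F` is one of three related compounds tested in an assay on isolated protein for displacement of a labelled ligand from metabotropic glutamate receptor 5 (Homo sapiens), with a stated time of 60 min, tested at 1 uM; on this read-out higher numbers stand for more inhibition at the one concentration tested (going by the name of the read-out) and lower numbers for less inhibition. In this assay compound 3 gives 89%, the second highest of the three numbers, though both neighbours lie within the scatter of it: compound 1 `Cc1ccc(S(=O)(=O)c2cnc3cc(F)ccc3c2N2CCC(C)CC2)cc1C` gives 90% and compound 2 `COc1ccc(S(=O)(=O)c2cnc3cc(F)ccc3c2N2CCC(C)CC2)cc1OC` gives 83%. Compound 4 `Cc1ccc(S(=O)(=O)c2cnc3cc(F)ccc3c2N2CCC(C)CC2)cc1` has not yet been measured. The change from compound 3 to compound 4 is hydrogen in place of fluoro on an aromatic carbon. For the measured compounds named here, no measured step removes a fluoro in this way; the nearest comparison is the step that put fluoro in place of methyl on an aromatic carbon, a number 1 percentage points lower from compound 1 to compound 3 (within the scatter), and the larger exchanges of the whole group on the sulfonyl sulfur, a number 6 percentage points higher from compound 2 to compound 3 (within the scatter) and a number 7 percentage points lower from compound 1 to compound 2 (within the scatter), also stayed within the scatter. Every change at this group so far has left the read-out close to that of compound 3, so no step beyond the scatter is expected here, and the estimate for compound 4 is a step of a number 1 percentage points lower from compound 3 to compound 4 (within the scatter), giving an expected 88% with a range from 78% to 96%.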

Compound 4, a percentage reported as inhibition, at one concentration (the size of the read-out at that concentration, not a potency): 88%
Estimate against measurement, compound 4: no gap at the digits printed; measured number inside the range.
By their numbers in this assay, from the lowest: compounds 2, 4, 3 and 1 (each within the scatter of the next).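

In this assay, for the compounds shown here, compound 4 gives the first reading with no substituent at this aromatic carbon, ortho to a methyl group: removing the fluoro gives a number 1 percentage points lower from compound 3 to compound 4 (within the scatter), and removing the methyl at the same place gives a number 2 percentage points lower from compound 1 to compound 4 (within the scatter). Hydrogen, fluoro and methyl at this position therefore cannot be told apart at the one concentration tested, so the read-out here does not depend on a substituent among these three, and the 4-methylphenyl group likewise stays within the scatter of the 3,4-dimethoxyphenyl group, with a number 5 percentage points higher from compound 2 to compound 4 (within the scatter). Nothing available bears on the reason for this.

Going by these compounds, whether a carboxylic acid or an amine at this position would keep the read-out this high remains open. So does whether these four compounds, which are compared at a single concentration, would also stay this close to one another at other concentrations.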